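Aryl exchange from compound 2 to compound 4

The source may report more compounds than this note shows. Statements on the series, on what has been measured and on what is new or still open speak of the compounds shown alone.

Measured so far in a functional assay on A549 cells (Homo sapiens) for inhibition, read by sulforhodamine B assay, with a stated time of 48 h, tested at 50 uM; a lower number here means less inhibition of growth, a higher number more inhibition of growth at the concentration tested
- compound 1 `CCCOc1ccc([C@@H]2CC(=O)c3cc(CC=C(C)C)c(OC)cc3O2)cc1` gives 43%
- compound 2 `COc1ccc([C@@H]2C/C(=N/OCc3cn(-c4ccc(Cl)cc4C)nn3)c3cc(CC=C(C)C)c(OC)cc3O2)cc1` gives 35%
- compound 3 `COc1cc2c(cc1CC=C(C)C)/C(=N/NC(N)=O)C[C@@H](c1ccc(O)cc1)O2` gives 77%

Compound 2 stands at 35%, and compound 1 at 43% lies within the scatter of it. Compound 3 at 77% lies beyond the scatter from compound 2.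

The next compound to read is compound 4 `COc1ccc([C@@H]2C/C(=N/OCc3cn(-c4cc(OC)c(OC)c(OC)c4)nn3)c3cc(CC=C(C)C)c(OC)cc3O2)cc1`. Its difference from compound 2 is 3,4,5-trimethoxyphenyl in place of 4-chloro-2-methylphenyl on an aromatic nitrogen, with 3,4,5-trimethoxyphenyl in place of 4-chloro-2-methylphenyl on an aromatic nitrogen of the five-membered aromatic ring with 3 nitrogen. The rest of the structure is unchanged.

Among the compounds with values here, no two measured compounds differ in only one place, so the series gives no measured size for a change of this kind. Compound 1 and compound 3 each differ from compound 2 in more than one place, and neither isolates this exchange. Within the data shown here, the best anchor is therefore compound 2 itself at 35%, the only measured compound that carries the aryl-bearing five-membered ring.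

In this assay the expected a number 5 percentage points higher from compound 2 to compound 4 (within the scatter) is small and slightly upward, with no change beyond the scatter anticipated. Compound 4 is estimated at 40%, with an expected range from 22% to 60%.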

Compound 4, percent growth inhibition at one concentration: 28%
For compound 4 the middle estimate is 12 percentage points above the measured one, and the stated range covers the measured number.
By their numbers in this assay, from the lowest: compounds 4, 2 and 1 (each within the scatter of the next, the first and the last beyond it); then compound 3.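

In this assay, within the data shown here, the exchange of 4-chloro-2-methylphenyl for 3,4,5-trimethoxyphenyl on an aromatic nitrogen of the five-membered aromatic ring with 3 nitrogen gives a number 7 percentage points lower from compound 2 to compound 4 (within the scatter), which is the first measured size for a change at this position. The entering group differs substantially by the computed counts, with 12 heavy atoms against 8, 3 hydrogen-bond acceptors against 0, and oxygen in place of chlorine, yet the step stays within the scatter, so this one pair shows no clear separation between the two aryl groups at the tested concentration. No measured information on these compounds bears on the reason for the size of this step.

Among these compounds, with only one pair at this position, the separate contributions of the chlorine, the methyl and the methoxy groups remain unresolved, as does the result for an unsubstituted phenyl. Also open, on these data alone, is whether a benzyl group, or a phenyl carrying a carboxylic acid or a dimethylamino group, on the same nitrogen would give a step beyond the scatter.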